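Chloro for Methyl on a Shared Core

The compounds below may be only part of what the source reports. "The series", "measured", "known", "first", "only" and "open" are said of these compounds alone.

Compound 2 `Cc1cn(COC(CO)CO)c2ncnc(N)c12` has been tested in an ADME assay on HFF cells (Homo sapiens) for cytotoxicity; a higher number here means a weaker inhibitor, a lower number a stronger inhibitor. In this assay compound 2 gives > 100000 nM, which is a limit of the assay rather than a number. Going by the values given here, its one measured neighbour, compound 1 `Nc1ncnc2c1c(I)cn2COC(CO)CO`, carries iodo where compound 2 carries methyl. In this assay compound 1 gives > 100000 nM, again a limit and not a number. The step that the two limits leave unreadable from compound 1 to compound 2 cannot be read for that reason. Both values fall under (the limit of > 100000 nM in this assay, at which 2 of the 2 values shown sit).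

Compound 3 `Nc1ncnc2c1c(Cl)cn2COC(CO)CO` differs from compound 2 by chloro in place of methyl on an aromatic carbon. Among the compounds with values here, no measured step bears on this exchange with a readable size; the only related step, from iodo to methyl, is hidden behind the two limits, and no value of a chloro-bearing compound is at hand. The expected step that the limit leaves unreadable from compound 2 to compound 3 is none beyond the scatter, with compound 3 most likely resting at the same limit as its neighbours. For compound 3 the estimate in this assay is 150000 nM, with a range from 50000 nM to 500000 nM.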

Compound 3, half-maximal inhibitory concentration: > 100000 nM
Compound 3: a limit, no number; the forecaster's own chance of this, stated with the estimate: 85%; the middle value is on the limit's open side.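

Compound 3 rests at the same assay limit as compound 1 and compound 2, so none of the steps among the three can be read: the limit of > 100000 nM in this assay, at which 3 of the 3 values shown sit.

The compounds shown leave open whether iodo, methyl and chloro on the shared core differ at all in this assay, and where any of the three would reach half-maximal inhibition.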